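Benzamido in Place of Phenyl: An Untested Step

The source may report more compounds than this note shows. Statements on the series, on what has been measured and on what is new or still open speak of the compounds shown alone.

In a functional assay on MCF7 cells (Homo sapiens) for antiproliferative activity, read by MTT assay (on this read-out lower numbers stand for stronger inhibition and higher numbers for weaker inhibition), compound 1 `COc1cc2c(Oc3ccc(NC(=O)Nc4ccccc4)cc3)ccnc2cc1OCCCCCCC(=O)NO` gives 1040 nM, the highest of the two numbers measured. Among the measured compounds shown here, compound 2 `COc1cc2c(Oc3ccc(NC(=O)Nc4ccc(C(F)(F)F)cc4Cl)cc3)ccnc2cc1OCCCCCCC(=O)NO` gives 500 nM; the only measured step is a 2.1-fold lower number from compound 1 to compound 2 (0.32 log units; beyond the scatter), with 2-chloro-4-(trifluoromethyl)phenyl in place of phenyl on an amide-type nitrogen. Compound 3 `COc1cc2c(Oc3ccc(NC(=O)NNC(=O)c4ccccc4)cc3)ccnc2cc1OCCCCCCC(=O)NO` carries the change (benzamido in place of phenyl on an amide-type nitrogen). For the measured compounds named here, no measured step covers this kind of change, and the one known step concerns a different replacement at the same position, so its size is no guide. Compound 3 is expected to show a step of a 1.2-fold higher number from compound 1 to compound 3 (0.06 log units; within the scatter). Compound 3 is therefore estimated at 1200 nM, within 400 nM to 3600 nM.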

Compound 3, half-maximal inhibitory concentration: 2450 nM
Beside the measured number, compound 3's estimate is 2.0-fold (0.31 log units) below it; the measured number falls inside the stated range.
By their numbers in this assay, from the lowest: compound 2; then compound 1; then compound 3.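

On the amide-type nitrogen, benzamido in place of phenyl brings a hydrogen-bond donor and acceptor that phenyl lacks, and it gives a 2.4-fold higher number from compound 1 to compound 3 (0.37 log units; beyond the scatter). So changes at this position can now be seen to move the number in both directions, and the gap is wider against the other replacement, with a 4.9-fold higher number from compound 2 to compound 3 (0.69 log units; beyond the scatter). No measurement on hand gives a cause for either step.

Still open, as far as these compounds go, is how a small group such as methyl on this nitrogen would compare. So is whether a benzamido ring carrying chlorine would bring the number down.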